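From compound 2 to compound 3: one side group changes

This account rests on a few compounds, and the source may have more. Where it says the series, first, only, none or still open, it means among the compounds named here.

Measured in an ADME assay on 2209-23 cells (Homo sapiens) for cytotoxicity, read by WST assay; on this read-out lower numbers stand for higher toxicity in this test and higher numbers for lower toxicity in this test:
- Compound 1 `O=c1c(C2=CS(=O)(=O)c3cc(F)ccc3N2)c(O)c2cc(F)ccc2n1Cc1ccc(F)cc1`: > 50000 nM
- Compound 2 `CS(=O)(=O)Nc1ccc2c(c1)S(=O)(=O)C=C(c1c(O)c3cc(F)ccc3n(Cc3ccc(F)c(Cl)c3)c1=O)N2`: > 50000 nM

Compound 2 gives > 50000 nM, which is a limit of the assay and not a number. Compound 1 gives > 50000 nM, which is also a limit. The measurements so far therefore show only (the limit of > 50000 nM in this assay, at which 2 of the 2 values shown sit), and compound 2 has no exact value to compare with.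

Compound 3 `CC(C)(C)CCn1c(=O)c(C2=CS(=O)(=O)c3cc(NS(C)(=O)=O)ccc3N2)c(O)c2cc(F)ccc21` keeps the shared core of compound 2 but changes one group: neopentyl in place of 3-chloro-4-fluorophenyl on a saturated chain carbon bound to an aromatic nitrogen. For the measured compounds named here, no measured pair shows what a change of this kind does in this assay.

The estimated a number no higher from compound 2 to compound 3 (the limit leaves the size open) is no change beyond the usual scatter. This expectation rests on compound 2, whose reading of > 50000 nM is a limit. Compound 3 is estimated at 50000 nM, with an expected range from 25000 nM to 100000 nM.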

Compound 3, half-maximal cytotoxic concentration: > 50000 nM
Compound 3 was reported as a limit (the forecaster's own chance of this, stated with the estimate: 80%); the middle value sits exactly at the limit.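

No step can be read from compound 2 to compound 3, because both readings are limits and not numbers: the limit of > 50000 nM in this assay, at which 3 of the 3 values shown sit.

The compounds shown leave open the exact values of all three, and so whether neopentyl in place of 3-chloro-4-fluorophenyl changes the half-maximal cytotoxic concentration at all.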